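A few compounds are considered here, and "the series" means these few. Any claim that something is new, unique, unknown or untested is made for them only; others in the source may bear on it.

Within the data shown here, in a functional assay on KYSE-410 cells (Homo sapiens) for antiproliferative activity, read by MTT assay, with a stated time of 72 h (a higher number here means a weaker inhibitor, a lower number a stronger inhibitor), compound 2 `O=C(Nc1cccc(F)c1)c1cc(=O)[nH]c2cc(-c3cccnc3F)ccc12` gives 11600 nM, the only true number among the measured compounds. Compound 1 `O=C(Nc1cccc(F)c1)c1cc(=O)[nH]c2cc(C3CC3)ccc12` reads > 20000 nM, which is a limit of the assay and not a number. Among the measured compounds shown here, only one measured step bears on what follows: an at least 1.7-fold lower number from compound 1 to compound 2 (0.23 log units; that floor lies within the scatter), in which 2-fluoropyridin-3-yl takes the place of cyclopropyl on an aromatic carbon. Compound 3 `C=Cc1ccc2c(C(=O)Nc3cccc(F)c3)cc(=O)[nH]c2c1` carries vinyl in place of 2-fluoropyridin-3-yl on an aromatic carbon. As the aromatic ring leaves again, a small step toward a higher number is expected in this assay, possibly none beyond the scatter. The expected change is a 1.5-fold higher number from compound 2 to compound 3 (0.17 log units; within the scatter). For compound 3 the estimated value is 17000 nM, within an expected range from 8000 nM to 30000 nM.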

Compound 3, half-maximal inhibitory concentration: 13600 nM
Compound 3: the middle estimate sits 1.3-fold (0.10 log units) above what was measured; the measured number falls inside the stated range.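

In this assay, the step of a 1.2-fold higher number from compound 2 to compound 3 (0.07 log units; within the scatter) shows that at this position, on an aromatic carbon of the shared core, removing the aromatic ring of 2-fluoropyridin-3-yl and setting vinyl in its place moves the number no further than the scatter. Compound 1 stands at a limit of the assay, > 20000 nM, so the step of an at least 1.4-fold lower number from compound 1 to compound 3 (0.16 log units; that floor lies within the scatter) is only a floor and does not set vinyl apart from cyclopropyl. That step stays open-ended because of the limit: the limit of > 20000 nM in this assay, at which 1 of the 3 values shown sits.

The compounds shown leave open whether an amine, a carboxylic acid or a longer carbon chain at this position would move the number beyond the scatter. They also leave open how far any group here can shift the number in either direction.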